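This account rests on a few compounds, and the source may have more. Where it says the series, first, only, none or still open, it means among the compounds named here.

Measured so far:
- compound 1, `O=C(c1cc(Cl)cc(Cl)c1)c1cc(Cl)ccc1OCCn1ccc(=O)[nH]c1=O`: 1900 nM in a physicochemical assay for solubility; a lower number here means a less soluble compound, a higher number a more soluble compound
- compound 2, `O=C(c1cc(F)cc(F)c1)c1cc(Cl)ccc1OCCn1ccc(=O)[nH]c1=O`: 7300 nM in this assay

Both compounds share a core and differ only in the aromatic ring attached to the carbonyl carbon. Among the measured compounds shown here, the single measured step, a 3.8-fold higher number from compound 1 to compound 2 (0.58 log units; beyond the scatter), shows that swapping the two chlorine atoms for two fluorine atoms on that ring raised solubility by a modest but real amount. For the measured compounds named here, compound 2 therefore stands as the more soluble of the two in this assay, with compound 1 the only comparison.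

Compound 3, `Cc1cc(C)cc(C(=O)c2cc(Cl)ccc2OCCn2ccc(=O)[nH]c2=O)c1`, has not been measured yet. The change on the way to it is 3,5-dimethylphenyl in place of 3,5-difluorophenyl on a carbonyl carbon. Going by the values given here, the only step known, that from compound 1 to compound 2, concerns halogens, not methyl groups, so it can guide the direction only loosely. A shift back toward the region of compound 1, or no step beyond the scatter, both seem plausible. The expectation for compound 3 in this assay is a drop of a 2.4-fold lower number from compound 2 to compound 3 (0.39 log units; beyond the scatter) relative to compound 2. The estimated value for compound 3 in this assay is 3000 nM, with a range from 1200 nM to 8000 nM.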

Compound 3, solubility: 3700 nM
The estimate for compound 3 lay 1.2-fold (0.09 log units) below the measured number; the range from low to high includes it.
By their numbers in this assay, from the lowest: compounds 1, 3 and 2 (each within the scatter of the next, the first and the last beyond it).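

With 3,5-dimethylphenyl on the carbonyl carbon, this assay shows that this position can carry a ring with no halogen on it and still give a number that cannot be told apart from those of the two halogen-bearing rings, with a 2.0-fold lower number from compound 2 to compound 3 (0.30 log units; within the scatter) and a 1.9-fold higher number from compound 1 to compound 3 (0.29 log units; within the scatter) as the two readings. The two halogen compounds remain separated by a 3.8-fold higher number from compound 1 to compound 2 (0.58 log units; beyond the scatter), yet compound 3 lies within the scatter of each, so these three rings give one firm difference and no clean ranking. No measurement here accounts for these numbers.

As far as these compounds go, it remains open how a ring bearing an amine or a carboxylic acid in place of these pairs would read in this assay, and whether any such group would give a step beyond the scatter from compound 2. Also open, from the compounds shown here alone, is how 3,5-dimethoxyphenyl or an unsubstituted phenyl would compare, which would show whether the pairs of groups on this ring matter at all for this read-out.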